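A Cyclopropylmethoxy Swap on a Glucagon Receptor Urea

The source may report more compounds than this note shows. Statements on the series, on what has been measured and on what is new or still open speak of the compounds shown alone.

Compound 1 `CC(C)(C)[C@H]1CC[C@H](N(Cc2ccc(C(=O)NCCC(=O)O)cc2)C(=O)Nc2ccc(Cl)c(Cl)c2)CC1` was examined in an in vitro assay on BHK cells for inhibition of Glucagon receptor (Homo sapiens) (a lower number here means a stronger inhibitor, a higher number a weaker inhibitor), where compound 1 gives 226 nM. Among the two numbers available, compound 1 stands lowest; its nearest neighbour, compound 2 `CCN(CC)C(=O)c1ccc(NC(=O)N(Cc2ccc(C(=O)NCCC(=O)O)cc2)[C@H]2CC[C@H](C(C)(C)C)CC2)cc1`, gives 2430 nM in this assay, a gap that lies beyond the usual scatter. Compound 3 `CC(C)(C)[C@H]1CC[C@H](N(Cc2ccc(C(=O)NCCC(=O)O)cc2)C(=O)Nc2ccc(OCC3CC3)cc2)CC1` has not yet been measured. It departs from compound 1 in one place: 4-(cyclopropylmethoxy)phenyl in place of 3,4-dichlorophenyl on an amide-type nitrogen. The entering group thus carries one hydrogen-bond acceptor where the leaving group carried none, and is larger by three heavy atoms.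

For the measured compounds named here, no measured pair shows this kind of change, so the expectation rests on compound 1 alone. The step from compound 1 to compound 3 is expected to be a modest weakening, a 2.0-fold higher number from compound 1 to compound 3 (0.30 log units; within the scatter), close to the edge of the scatter. Compound 3 is therefore estimated to give 450 nM in this assay, within a range from 130 nM to 1600 nM.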

Compound 3, half-maximal inhibitory concentration: 140 nM
For compound 3 the middle estimate is 3.2-fold (0.51 log units) above the measured one; measured number inside the range.
By their numbers in this assay, from the lowest: compounds 3 and 1 (each within the scatter of the next); then compound 2.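

In this assay, 4-(cyclopropylmethoxy)phenyl on the amide-type nitrogen and 3,4-dichlorophenyl cannot be told apart, with a 1.6-fold lower number from compound 1 to compound 3 (0.21 log units; within the scatter), so this place accepts two quite different aryl groups with no clear difference in the number. The result also shows that the place is not indifferent to what the phenyl ring carries: cyclopropylmethoxy in place of diethylcarbamoyl on an aromatic carbon gives a 17-fold lower number from compound 2 to compound 3 (1.24 log units; beyond the scatter), a large step. No measurement accompanies these numbers that could explain either step.

The compounds shown do not separate the share of the ether oxygen from that of the cyclopropyl ring, which a plain methoxy or a cyclopropylmethyl group could address. They also leave open how an amine or a carboxylic acid on that phenyl ring would read.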